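The compounds below may be only part of what the source reports. "The series", "measured", "known", "first", "only" and "open" are said of these compounds alone.

Working notes on the quinolinyl thiosemicarbazone series.

Compound 1 `COc1ccc(C)cc1NC(=S)N/N=C/c1ccc2ccccc2n1` and compound 2 `N#Cc1ccc(NC(=S)N/N=C/c2ccc3ccccc3n2)cc1` share the core and differ in the aryl group on the thiourea nitrogen. In a functional assay on HeLa cells (Homo sapiens) for antiproliferative activity, read by sulforhodamine B assay, with a stated time of 72 h (a lower number here means a stronger inhibitor, a higher number a weaker inhibitor), compound 1 gives only a limit, > 100000 nM, and not a number. Going by the values given here, compound 2 gives 20000 nM in this assay, the only actual number among the values shown. Among the compounds with values here, no step between two measured compounds can be counted here, since the two aryl groups differ in more than one place; the limit of > 100000 nM in this assay, at which 1 of the 2 values shown sits, at the upper end of the assay is the one firm point of reference beside compound 2.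

Compound 3 `Fc1cccc(NC(=S)N/N=C/c2ccc3ccccc3n2)c1` is not yet measured. It differs from compound 2 at one place: 3-fluorophenyl in place of 4-cyanophenyl on an amide-type nitrogen. Within the data shown here, the change removes the nitrile-bearing ring and brings in a ring with a single fluorine; nothing among the measured values speaks directly to this swap. The expected step from compound 2 to compound 3 in this assay is a 2.0-fold higher number from compound 2 to compound 3 (0.30 log units; within the scatter), a modest loss that may well lie within the scatter. Compound 3 is therefore expected to give about 40000 nM, somewhere between 10000 nM and 150000 nM, with a real chance of landing at the limit.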

Compound 3, half-maximal inhibitory concentration: 70100 nM
Compound 3: the middle estimate sits 1.8-fold (0.24 log units) below what was measured; the range from low to high includes it.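

In this assay, the series now has its first countable step, a 3.5-fold higher number from compound 2 to compound 3 (0.54 log units; beyond the scatter), which marks the aryl group on the thiourea nitrogen as a place where a single change can be read beyond the scatter. The direction is towards weaker inhibition on going from 4-cyanophenyl to 3-fluorophenyl, although the two groups differ both in the substituent and in the number of its position, and this one step does not separate those two changes. Compound 1 gives only a limit and not a number, which means that little of the assay's range remains for reading any further loss on this nitrogen: the limit of > 100000 nM in this assay, at which 1 of the 3 values shown sits.

The compounds shown leave open how 3-cyanophenyl and 4-fluorophenyl would read in this assay, the pair that would tell the substituent apart from its position. They also leave open whether a phenyl ring carrying an amine or a carboxylic acid on this nitrogen would move the number in the opposite direction, towards stronger inhibition than compound 2 shows.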